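This account rests on a few compounds, and the source may have more. Where it says the series, first, only, none or still open, it means among the compounds named here.

Measured so far:
- compound 1, `COc1ccc(N2C(=O)COc3ccc(-c4cnc(OC)c(NS(=O)(=O)c5ccc(F)cc5)c4)cc32)cc1`: 18400 nM
- compound 2, `Cc1ccc(N2C(=O)COc3ccc(-c4cnc(Cl)c(NS(=O)(=O)c5ccc(F)cc5)c4)cc32)cc1`: 38900 nM

Both numbers come from a functional assay on A-375 cells (Homo sapiens) for antiproliferative activity, read by MTT assay, with a stated time of 72 h; on this read-out lower numbers stand for stronger inhibition and higher numbers for weaker inhibition. Among the two compounds measured here, compound 1 stands at the lowest number, and compound 2 stands at a higher one; the gap between them lies beyond the usual scatter of such measurements, so compound 1 is the stronger of the pair on this read-out.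

Compound 3, `COc1ncc(-c2ccc3c(c2)NC(=O)CO3)cc1NS(=O)(=O)c1ccc(F)cc1`, has not yet been measured. It differs from compound 1 in one place: hydrogen in place of 4-methoxyphenyl on an amide-type nitrogen in a ring. The ring carrying the carbonyl is otherwise kept, as is the sulfonamide-bearing side of the molecule.

Among the measured compounds shown here, no measured pair in this set shows what removing a group from that nitrogen does, so the direction of the step can only be guessed. Compound 3 is expected to show a weaker result than compound 1, with a step of a 2.4-fold higher number from compound 1 to compound 3 (0.39 log units; beyond the scatter) that goes beyond the scatter. For compound 3 the expected value is 45000 nM, within a range from 12000 nM to 170000 nM.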

Compound 3, half-maximal inhibitory concentration: 26300 nM
Estimate against measurement, compound 3: 1.7-fold (0.23 log units) above; measured number inside the range.
By their numbers in this assay, from the lowest: compounds 1, 3 and 2 (each within the scatter of the next, the first and the last beyond it).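

In this assay, replacing the 4-methoxyphenyl on the amide-type nitrogen in the ring with a bare hydrogen gives a 1.4-fold higher number from compound 1 to compound 3 (0.16 log units; within the scatter), so this read-out does not separate the two compounds. The earlier compounds shown here could not show this: a group of 8 heavy atoms, including a whole aromatic ring, can leave this nitrogen without a shift larger than the ordinary variation between repeated measurements, so the 4-methoxyphenyl is not required to keep this level of activity. Nothing in the data shown explains why the number stays within that variation.

As far as these compounds go, it remains open whether any group on this nitrogen could move the number beyond that variation, for example a short ethyl chain, a chain ending in an amine, or a chain ending in a carboxylic acid. From the compounds shown here alone, it is also open whether the same swap would give a similar result if the sulfonamide-bearing side of the molecule carried something else, such as an amine in place of the fluorine.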